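The source may hold more compounds than are shown below. What is called first, only, known or untested is meant among the compounds shown, and "the series" means these compounds.

Compound 1, whose structure is `CC/C=C\C/C=C\C/C=C\CCCCCCCC1(O)CC(=O)c2c(O)cc(OCOC)cc2O1`, is a partly saturated ring-fused core carrying a long unsaturated chain. In a functional assay on MCF7 cells (Homo sapiens) for antiproliferative activity, read by MTT assay (on this read-out lower numbers stand for stronger inhibition and higher numbers for weaker inhibition), compound 1 gives 17500 nM. Compound 2, with the structure `CCCC/C=C\CCCCCCCCCC1(O)CC(=O)c2c(O)cc(OCOC)cc2O1`, differs from it by a group of 8 heavy atoms (8 carbon; no ring) in place of a group of 10 heavy atoms (10 carbon; no ring), on a saturated chain carbon, seven bonds along the chain from a saturated ring carbon, and in this assay compound 2 gives 43200 nM. That change produced a 2.5-fold higher number from compound 1 to compound 2 (0.39 log units; beyond the scatter), so the shorter chain with a single double bond went with weaker inhibition.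

Compound 3, whose structure is `CC/C=C\C/C=C\C/C=C\CCCCCCCc1cc(=O)c2c(O)c(C)c(OCOC)c(C)c2o1`, carries the same long chain on a different core, one that is aromatic and bears two methyl groups. How the core of compound 3 differs from the core of compound 1 is not broken down here. In this assay compound 3 reaches only the limit of the measurement, reported as > 84100 nM, rather than a number. This is the limit of > 84100 nM in this assay, at which 1 of the 3 values shown sits.

Compound 4, with the structure `CCCC/C=C\CCCCCCCCCc1cc(=O)c2c(O)c(C)c(OCOC)c(C)c2o1`, is obtained from compound 3 by a group of 8 heavy atoms (8 carbon; no ring) in place of a group of 10 heavy atoms (10 carbon; no ring), on a saturated chain carbon, seven bonds along the chain from an aromatic carbon. This is the same kind of change as that from compound 1 to compound 2, though here the place is seven bonds along the chain from an aromatic carbon rather than from a saturated ring carbon. Since compound 3 already sits at the limit, and the same kind of change weakened compound 1, compound 4 is expected to sit at or beyond that limit, a step estimated as a step that the limit leaves unreadable from compound 3 to compound 4. Compound 4 is therefore estimated at 150000 nM, within a range of 84100 nM to 400000 nM.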

Compound 4, half-maximal inhibitory concentration: > 67200 nM
Compound 4 ended at the assay's limit (the forecaster's own chance of this, stated with the estimate: 85%); the middle value lies beyond the limit too.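

In this assay compound 4 gives only a limit of the measurement, > 67200 nM, not a number. Compound 3 also sits at a limit, so the step between compound 3 and compound 4 cannot be read. From the compounds shown here alone, what stays open is whether oct-3-en-1-yl in place of the longer chain changes inhibition on this core, as it did between compound 1 and compound 2.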